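The source may hold more compounds than are shown below. What is called first, only, known or untested is meant among the compounds shown, and "the series" means these compounds.

Compound 2 `Cc1ccc(Nc2nc(N)c(C(=O)c3ccccc3)s2)cc1` and compound 4 `Nc1nc(Nc2ccc(Cl)cc2)sc1C(=O)c1ccccc1` share their core with compound 1 `COc1ccc(C(=O)c2sc(Nc3ccccc3)nc2N)cc1OC` and compound 3 `COc1cc(C(=O)c2sc(Nc3ccccc3)nc2N)cc(OC)c1OC`; all four carry a carbonyl and an anilino group on that core and differ only in the substituents on their outer rings. In a functional assay on FM3A cells (Mus musculus) for antiproliferative activity, read by cell counting, with a stated time of 2 days (on this read-out higher numbers stand for weaker inhibition and lower numbers for stronger inhibition), compound 1 gives only a limit, > 10000 nM, which is the case described by the limit of > 10000 nM in this assay, at which 1 of the 3 values shown sits. In this assay compound 3 gives 23 nM. In this assay compound 2 gives 1500 nM, so of the two numbers that are not limits compound 2 stands at the higher one, meaning weaker inhibition than compound 3. Among the measured compounds shown here, the only step between compounds that differ in a single place is an at least 430-fold lower number from compound 1 to compound 3 (2.63 log units; beyond the scatter), and it concerns a methoxy group entering where hydrogen stood. The change from compound 2 to compound 4 is of another kind: chloro in place of methyl on an aromatic carbon. No measured step shows an exchange of a methyl for a chloro, so nothing shown bears directly on this change. With nothing to point in either direction, the step expected from compound 2 to compound 4 is no change at the digits printed from compound 2 to compound 4 (within the scatter), within the scatter. Compound 4 is therefore estimated at 1500 nM, with a range from 500 nM to 4500 nM.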

Compound 4, half-maximal inhibitory concentration: > 10000 nM
Compound 4 ended at the assay's limit; the forecaster's own chance of this, stated with the estimate: 5%; middle value at least 6.6-fold (0.82 log units) away from the limit.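

In this assay the exchange of 4-methylphenyl for 4-chlorophenyl gives an at least 6.6-fold higher number from compound 2 to compound 4 (0.82 log units; beyond the scatter) and so moves the read-out toward weaker inhibition, although only one heavy atom is swapped for one heavy atom and neither group counts a hydrogen-bond donor or acceptor. Among the compounds shown here, the only earlier step was methoxy in place of hydrogen, and it went toward a lower number, so this is the first sign that a change on this aromatic carbon, para to a large group, can matter and that a single change can also cost activity. Compound 4 gives > 10000 nM, which is a limit, and such limits are not rare among these compounds: the limit of > 10000 nM in this assay, at which 2 of the 4 values shown sit.

On these data alone, what an amine, a carboxylic acid or a longer chain would do on this same aromatic carbon stays open, so one exchange cannot say whether methyl is specially favoured or chloro specially poor. Also open, as far as these compounds go, is whether the same exchange would have a similar effect with the three methoxy groups of compound 3 on the other outer ring.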